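The compounds below may be only part of what the source reports. "The series", "measured", "known", "first", "only" and "open" are said of these compounds alone.

Compound 1 `CNc1ncnc2c1c(-c1ccoc1)cn2[C@@H]1O[C@H](CO)[C@@H](O)[C@H]1O` in a functional assay on HL-60 cells (Homo sapiens) for antiproliferative activity, read by XTT assay, with a stated time of 72 h (on this read-out lower numbers stand for stronger inhibition and higher numbers for weaker inhibition), gives > 15000 nM, which is a limit of the assay rather than a number.
Compound 2 `CNc1ncnc2c1c(-c1cc3ccccc3o1)cn2[C@@H]1O[C@H](CO)[C@@H](O)[C@H]1O` in this assay gives 8950 nM.
Compound 3 `Nc1nc(N)c2c(-c3ccoc3)cn([C@@H]3O[C@H](CO)[C@@H](O)[C@H]3O)c2n1` in this assay gives > 20000 nM, again a limit of the assay and not a number.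

Compounds 1 and 2 share one core and differ in a single place: 1-benzofuran-2-yl in place of furan-3-yl on an aromatic carbon. This change gave an at least 1.6-fold lower number from compound 1 to compound 2 (0.22 log units; that floor lies within the scatter). Compound 3 carries a different core, and the difference between the two cores is not broken down here. Compound 4 `Nc1nc(N)c2c(-c3cc4ccccc4o3)cn([C@@H]3O[C@H](CO)[C@@H](O)[C@H]3O)c2n1` has not been measured; it stands to compound 3 exactly as compound 2 stands to compound 1, the same change at the same place: 1-benzofuran-2-yl in place of furan-3-yl on an aromatic carbon. For compound 4 a step of about the size seen before is expected, an at least 1.6-fold lower number from compound 3 to compound 4 (0.22 log units; that floor lies within the scatter), resting on the step from compound 1 to compound 2, an at least 1.6-fold lower number from compound 1 to compound 2 (0.22 log units; that floor lies within the scatter). Compound 4 is thus estimated at 12000 nM, most likely between 4000 nM and 40000 nM, with a real chance that only a limit is reported again.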

Compound 4, half-maximal inhibitory concentration: > 15000 nM
Compound 4 gave a limit, no number; the forecaster's own chance of this, stated with the estimate: 55%; middle value at least 1.2-fold (0.09 log units) from the limit.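

Compound 3 and compound 4 each give only a limit of the assay, not a number, and the step between them cannot be read. The compounds shown leave open whether 1-benzofuran-2-yl in place of furan-3-yl changes the number at all on the core of compound 3.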